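Isopropyl in Place of Phenyl: Compound 3 Expected at the Limit

The compounds below may be only part of what the source reports. "The series", "measured", "known", "first", "only" and "open" are said of these compounds alone.

Compound 2 `CC(C)n1nc(-c2cc(-c3ccccc3)on2)c2c(N)ncnc21` gives in an assay on TT cells for inhibition of proto-oncogene tyrosine-protein kinase receptor Ret variant C634W (Homo sapiens), read by MTT assay, with a stated time of 10 days (a lower number here means a stronger inhibitor of growth, a higher number a weaker inhibitor of growth), only a limit and not a number, > 10000 nM. Compound 1 `CC(C)n1nc(-c2cc(C3CCCCC3)on2)c2c(N)ncnc21` likewise gives only a limit in this assay, > 10000 nM. The step that the two limits leave unreadable from compound 1 to compound 2 is therefore unreadable, since the limit of > 10000 nM in this assay, at which 2 of the 2 values shown sit, covers both values shown. Compound 3 `CC(C)c1cc(-c2nn(C(C)C)c3ncnc(N)c23)no1` differs from compound 2 by isopropyl in place of phenyl on an aromatic carbon. Within the data shown here, no measured step bears on this change with a readable size, so no direction can be drawn from it; compound 3 is expected to remain at the limit as well, and the expected step of a number no higher from compound 2 to compound 3 (the limit leaves the size open) reflects that. The estimate for compound 3 is 10000 nM, between 3000 nM and 30000 nM.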

Compound 3, concentration for 50% growth inhibition: 5130 nM
The estimate for compound 3 lay 1.9-fold (0.29 log units) above the measured number; measured number inside the range.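

On the aromatic carbon next to the ring oxygen, isopropyl is the first group shown to give a number rather than a limit in this assay for this series. With the shared core unchanged, isopropyl in place of phenyl gives an at least 1.9-fold lower number from compound 2 to compound 3 (0.28 log units; that floor lies within the scatter) and isopropyl in place of cyclohexyl gives an at least 1.9-fold lower number from compound 1 to compound 3 (0.28 log units; that floor lies within the scatter) on this same carbon. The compounds shown leave open whether methyl, a longer chain or an amine on this carbon would give a number, and in which direction it would lie. On these data alone, the true size of both steps also stays open: the limit of > 10000 nM in this assay, at which 2 of the 3 values shown sit.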